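Carboxy for methylsulfonyl on a thiazolopyrimidine anilide

The source may hold more compounds than are shown below. What is called first, only, known or untested is meant among the compounds shown, and "the series" means these compounds.

Measured so far:
- compound 1 `Clc1cccc(Cl)c1Nc1nc2c(Nc3ccccc3)ncnc2s1` gives 170 nM in a functional assay on HEK293 cells for antagonist activity at transient receptor potential cation channel subfamily V member 1 (Rattus norvegicus), read by calcium flux; a lower number here means a stronger inhibitor, a higher number a weaker inhibitor
- compound 2 `CS(=O)(=O)c1ccc(Nc2ncnc3sc(Nc4c(Cl)cccc4Cl)nc23)cc1` gives 3 nM in this assay

Going by the values given here, compound 2 stands at the lowest number of the two measured in this assay; its nearest neighbour is compound 1, and the one measured step, a 57-fold lower number from compound 1 to compound 2 (1.75 log units; beyond the scatter), separates them. That step says that a methylsulfonyl group on the outer aromatic ring, in place of a hydrogen, lowers the number far beyond the scatter.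

Compound 3 `O=C(O)c1ccc(Nc2ncnc3sc(Nc4c(Cl)cccc4Cl)nc23)cc1` is not yet measured. It differs from compound 2 in one place: carboxy in place of methylsulfonyl on an aromatic carbon. Among the compounds with values here, no measured step shows a carboxy group at this position, so the only guide is that the position itself matters, as a 57-fold lower number from compound 1 to compound 2 (1.75 log units; beyond the scatter) shows. A carboxy group is not a methylsulfonyl group, so part of the gain seen from compound 1 to compound 2 may not carry over, while a substituent is still present there. A moderate rise in the number from compound 2 to compound 3 is therefore expected, a 10-fold higher number from compound 2 to compound 3 (1.00 log units; beyond the scatter), with wide uncertainty. For compound 3 in this assay the expected value is 30 nM, within a range from 5 nM to 200 nM.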

Compound 3, half-maximal inhibitory concentration: > 5000 nM
Compound 3 gave a limit, no number; the forecaster's own chance of this, stated with the estimate: 5%; at least 160-fold (2.22 log units) between middle value and limit.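

In this assay compound 3 gives no number, only a limit: the limit of > 5000 nM in this assay, at which 1 of the 3 values shown sits. Putting carboxy in place of methylsulfonyl on this aromatic carbon gives an at least 1600-fold higher number from compound 2 to compound 3 (3.22 log units; beyond the scatter), so the earlier gain cannot be credited to simply having a substituent here; among the compounds shown, it goes with the methylsulfonyl group alone. Nor does carboxy merely lose that gain: compared with plain hydrogen, it gives an at least 29-fold higher number from compound 1 to compound 3 (1.46 log units; beyond the scatter), which shows that a change at this one place can move the number far in either direction, and that a group here can leave a compound a weaker inhibitor than no group at all.

From the compounds shown here alone, with only a limit for compound 3, the full size of both steps remains unknown, and three compounds cannot show how the number changes across a wider range of groups. Going by these compounds, it remains open whether a sulfonamide, a carboxamide or a methyl ester on this carbon would stay close to compound 2 or fall towards compound 3.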